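This account rests on a few compounds, and the source may have more. Where it says the series, first, only, none or still open, it means among the compounds named here.

Measured in a functional assay on HepG2 cells (Homo sapiens) for antiproliferative activity, read by MTT assay, with a stated time of 72 h; on this read-out higher numbers stand for weaker inhibition and lower numbers for stronger inhibition:

Compound 1 `N#Cc1ccc(/C=N/NC(=O)Nc2ccc(Oc3ccnc4[nH]ccc34)c(F)c2)cc1`: 850 nM
Compound 2 `O=C(N/N=C/c1cccc([N+](=O)[O-])c1)Nc1ccc(Oc2ccnc3[nH]ccc23)c(F)c1`: 5180 nM
Compound 3 `O=C(N/N=C/c1ccc(O)cc1)Nc1ccc(Oc2ccnc3[nH]ccc23)c(F)c1`: 1950 nM

Of these three, compound 3 stands second highest at 1950 nM. Its nearest neighbour is reached by the step of a 2.3-fold higher number from compound 1 to compound 3 (0.36 log units; beyond the scatter), and its furthest by the step of a 2.7-fold lower number from compound 2 to compound 3 (0.42 log units; beyond the scatter).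

Compound 4 `CN(C)CCn1cccc1/C=N/NC(=O)Nc1ccc(Oc2ccnc3[nH]ccc23)c(F)c1` has not yet been measured. It carries 1-(2-(dimethylamino)ethyl)-1H-pyrrol-2-yl in place of 4-hydroxyphenyl on a carbon with a double bond to nitrogen. All three measured steps alter the group on this same carbon, and all are modest. The largest is the step of a 6.1-fold higher number from compound 1 to compound 2 (0.78 log units; beyond the scatter). Among the measured compounds shown here, none of the measured compounds has a five-membered aromatic ring or a dimethylamino group here, so the new group lies outside what has been tested and the data give no firm direction. On the size of the step of a 6.1-fold higher number from compound 1 to compound 2 (0.78 log units; beyond the scatter), a change no larger than that is expected, and quite possibly a smaller one. The expected step is a 1.5-fold lower number from compound 3 to compound 4 (0.18 log units; within the scatter), which amounts to no confident shift either way. In this assay compound 4 is estimated at 1300 nM, with an expected range from 300 nM to 5000 nM.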

Compound 4, half-maximal inhibitory concentration: 8980 nM
Compound 4: the middle estimate sits 6.9-fold (0.84 log units) below what was measured; measured number outside the range, above it.
By their numbers in this assay, from the lowest: compound 1; then compound 3; then compounds 2 and 4 (each within the scatter of the next).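

In this assay, among the compounds shown here, the carbon with a double bond to nitrogen now shows a large step for the first time: putting 1-(2-(dimethylamino)ethyl)-1H-pyrrol-2-yl in place of 4-cyanophenyl gives an 11-fold higher number from compound 1 to compound 4 (1.02 log units; beyond the scatter) whereas all the earlier steps at this carbon were modest. The same group in place of 4-hydroxyphenyl gives a 4.6-fold higher number from compound 3 to compound 4 (0.66 log units; beyond the scatter) so this first group with a five-membered aromatic ring falls short of both compounds with a para-free description of 4-substituted phenyl, while compound 1 remains the most potent of the set. Against 3-nitrophenyl the picture differs, since a 1.7-fold higher number from compound 2 to compound 4 (0.24 log units; within the scatter) leaves the new group and 3-nitrophenyl indistinguishable in this read-out, and no measurement at hand gives a reason for any of these steps.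

The change replaces the ring and adds the chain in one move, so the compounds shown leave open which of the two goes with the higher number. An unsubstituted 1H-pyrrol-2-yl group, or a phenyl ring carrying the same 2-(dimethylamino)ethyl chain, would separate these two parts, and a morpholine at the end of the chain would test whether the dimethylamino group itself matters.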